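Swapping a Methoxypyridine for a Furan on a Shared Core

The source may hold more compounds than are shown below. What is called first, only, known or untested is meant among the compounds shown, and "the series" means these compounds.

Measured so far:
- compound 1, `CNc1nc(NCCCN(C)C)c2sc(-c3ccc(OC)nc3)cc2n1`: 10 uL/min
- compound 2, `CNc1nc(NCCCN(C)C)c2sc(-c3ccc(N4CCNCC4)cc3)cc2n1`: 36 uL/min
- compound 3, `CNc1nc(NCCCN(C)C)c2sc(-c3cccc(C(F)(F)F)c3)cc2n1`: 55.8 uL/min

Of the compounds shown here, three built on the same core have been tested in an ADME assay (liver) for metabolic stability, with Liver microsome (Homo sapiens) as the target, read by LC-MS, using microsomes, tested at 1 uM; a higher number here means faster removal of the compound, a lower number slower removal. Compound 1 gives 10 uL/min, the lowest number of the three, so it is removed most slowly in this assay. Compound 2 gives 36 uL/min and compound 3 gives 55.8 uL/min; both lie clearly above compound 1, beyond the usual scatter. The three differ only in the aromatic group attached to the core, and no single change among them is isolated as a step, so the measured values alone show that this group can move the number over a wide span.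

The next compound, compound 4, `CNc1nc(NCCCN(C)C)c2sc(-c3ccoc3)cc2n1`, is not yet measured. It differs from compound 1 in one place: furan-3-yl in place of 6-methoxypyridin-3-yl on an aromatic carbon. Since compound 1 sits at the slow end and the two other aromatic groups both push the number up, a modest rise in this assay is expected, though not one as large as for compound 3. Compound 4 is expected to show a 2.5-fold higher number from compound 1 to compound 4 (0.40 log units; beyond the scatter). The estimate for compound 4 in this assay is 25 uL/min, with a likely range from 10 uL/min to 60 uL/min.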

Compound 4, intrinsic clearance in a liver preparation (reported as CLH), per the amount of preparation that the assay uses: 33.3 uL/min
Beside the measured number, compound 4's estimate is 1.3-fold (0.12 log units) below it; the range from low to high includes it.
By their numbers in this assay, from the lowest: compound 1; then compounds 4, 2 and 3 (each within the scatter of the next).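

Placed in this assay, the swap of 6-methoxypyridin-3-yl for furan-3-yl on the aromatic carbon next to the ring sulfur gives a 3.3-fold higher number from compound 1 to compound 4 (0.52 log units; beyond the scatter) and provides the first single-place change at this position. Among the compounds shown here, the earlier compounds showed only that different aromatic groups here came with different numbers, whereas this step ties a rise beyond the usual scatter to one defined replacement on the shared core. The replacement changes several things at once, however, since a five-membered aromatic ring with an oxygen enters and a six-membered aromatic ring with a nitrogen and a methoxy group leaves, and nothing shown gives a reason for the rise.

The compounds shown leave open which of those differences accounts for the step, a question that a plain pyridine ring without the methoxy group or a benzene ring carrying a methoxy group could help to separate. On these data alone, it also remains open whether the step is particular to furan-3-yl or would be shared by another five-membered aromatic ring, such as a thiophene or a pyrazole.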